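The source may report more compounds than this note shows. Statements on the series, on what has been measured and on what is new or still open speak of the compounds shown alone.

Three compounds have so far been examined in an ADME assay on microsomes from liver (Mus musculus) for metabolic stability, read by LC-MS, using NADPH, tested at 1 uM; on this read-out higher numbers stand for a longer-lived compound and lower numbers for a shorter-lived compound. Compound 1 `CCOC(=O)NC/C=C\CN(C)C[C@H]1O[C@@H](n2c(C)nc3c(N)ncnc32)[C@H](O)[C@@H]1O` is the starting point. In this assay compound 1 gives > 1.5 h, which is a limit of the assay rather than a number. Compound 2 `Cc1nc2c(N)ncnc2n1[C@@H]1O[C@H](CN(C)C/C=C\CNC(=O)OC(C)C)[C@@H](O)[C@H]1O` differs from compound 1 by a single change, (methyl in place of hydrogen on a saturated chain carbon bound to an oxygen next to a carbonyl group and a saturated chain carbon). In this assay compound 2 gives > 1.5 h, again a limit of the assay. The step that the two limits leave unreadable from compound 1 to compound 2 cannot be sized because of the limit of > 1.5 h in this assay, at which 3 of the 3 values shown sit.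

Compound 3 `CC(=O)NC/C=C\CN(C)C[C@H]1O[C@@H](n2cnc3c(N)ncnc32)[C@H](O)[C@@H]1O` is built on a different core; the difference between the two cores is not broken down here. In this assay compound 3 gives > 1.5 h, which is also a limit of the assay.

Compound 4 `CCC(=O)NC/C=C\CN(C)C[C@H]1O[C@@H](n2cnc3c(N)ncnc32)[C@H](O)[C@@H]1O` has not yet been measured. It differs from compound 3 by methyl in place of hydrogen on a saturated chain carbon bound to a carbonyl carbon. For the measured compounds named here, this is the same kind of change as the one from compound 1 to compound 2, but not the same: there the place was a saturated chain carbon bound to an oxygen next to a carbonyl group and a saturated chain carbon, while here it is a saturated chain carbon bound to a carbonyl carbon.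

The step that the limit leaves unreadable from compound 3 to compound 4 is expected to be small. The estimate for compound 4 in this assay is 2.5 h, expected to lie between 1.2 h and 5 h. That expectation rests on compound 3 giving > 1.5 h and on a step that the two limits leave unreadable from compound 1 to compound 2.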

Compound 4, half-life: > 1.5 h
Compound 4: only a limit was reported; the forecaster's own chance of this, stated with the estimate: 75%; the middle value is on the limit's open side.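

No step can be read between compound 3 and compound 4: the change from acetyl to propanoyl has no measurable size, because both compounds give only a limit of the assay and not a number: the limit of > 1.5 h in this assay, at which 4 of the 4 values shown sit.

The compounds shown leave open how long any of them actually lasts in this assay, and whether adding a methyl in either place alters that half-life at all.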